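Furan-2-yl in place of methoxy on the shared core

This account rests on a few compounds, and the source may have more. Where it says the series, first, only, none or still open, it means among the compounds named here.

In a functional assay on cells (Homo sapiens), read by thymidine incorporation (a lower number here means a stronger inhibitor, a higher number a weaker inhibitor), compound 1 `CNc1cc(NCc2cccnc2)n2ncc(Br)c2n1` gives 1200 nM and compound 2 `COc1cc(NCc2cccnc2)n2ncc(Br)c2n1` gives 2000 nM. Among the measured compounds shown here, compound 2 therefore stands within the scatter of its only neighbour, with a 1.7-fold higher number from compound 1 to compound 2 (0.22 log units; within the scatter).

Compound 3 `Brc1cnn2c(NCc3cccnc3)cc(-c3ccco3)nc12` carries furan-2-yl in place of methoxy on an aromatic carbon. For the measured compounds named here, the sole measured step, a 1.7-fold higher number from compound 1 to compound 2 (0.22 log units; within the scatter), brings in no ring, so it is only a weak guide here. No direction can be argued from it, and no shift beyond the scatter is expected in this assay. The estimated step is a 1.3-fold lower number from compound 2 to compound 3 (0.12 log units; within the scatter). Compound 3 is expected at 1500 nM, with an estimated range of 300 nM to 6000 nM.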

Compound 3, half-maximal inhibitory concentration: 15200 nM
Compound 3: the middle estimate sits 10-fold (1.01 log units) below what was measured; the whole stated range lies below it.
By their numbers in this assay, from the lowest: compounds 1 and 2 (each within the scatter of the next); then compound 3.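

In this assay this aromatic carbon does not accept every group equally: furan-2-yl gives a clear rise (a 7.6-fold higher number from compound 2 to compound 3 (0.88 log units; beyond the scatter)) and a larger one against methylamino (a 13-fold higher number from compound 1 to compound 3 (1.10 log units; beyond the scatter)), while methoxy and methylamino remain within the scatter of each other. Of the three groups shown, only the one carrying a ring moves the number beyond the scatter. Nothing available accounts for this rise.

Open, on these data alone, is whether the rise belongs to any aromatic ring at this carbon or to furan-2-yl alone. Phenyl, morpholine or a short chain such as ethyl would help separate these cases.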